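Hydrogen to 4-chlorophenyl: what compound 4 may show

The compounds below may be only part of what the source reports. "The series", "measured", "known", "first", "only" and "open" are said of these compounds alone.

In a functional assay on DLD-1 cells (Homo sapiens) for inhibition, read by MTT assay, with a stated time of 72 h (on this read-out higher numbers stand for weaker inhibition and lower numbers for stronger inhibition), compound 1 `COc1ccc(CCCNCc2c(OC)cc(Oc3ccc(Nc4ccccc4)cc3)cc2OC)cc1` gives 4650 nM and compound 2 `COc1cc(Oc2cccc(Nc3ccccc3)c2)cc(OC)c1CNCc1ccc(F)cc1` gives 2650 nM while compound 3 `CNCc1c(OC)cc(Oc2cccc(Nc3ccccc3)c2)cc1OC` gives 11900 nM as the highest number and so the weakest inhibition of the three. Compound 4 `COc1cc(Oc2cccc(Nc3ccccc3)c2)cc(OC)c1CNCc1ccc(Cl)cc1` has not been measured yet. Its structure puts 4-chlorophenyl in place of hydrogen on a saturated chain carbon bound to an amine nitrogen and leaves the rest of compound 3 as it is.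

Among the measured compounds shown here, only one measured step bears on this change. In that step 4-fluorophenyl gives way to hydrogen at the same place, and the result is a 4.5-fold higher number from compound 2 to compound 3 (0.65 log units; beyond the scatter) which is a modest change but a real one. For the measured compounds named here, compound 1 is tied to the others by no single-change step, so it adds little here. Read backwards, the one step suggests that putting an aromatic ring back at this place should lower the number in this assay by a similar amount, though a single pair is thin evidence. The expected change is a 4.6-fold lower number from compound 3 to compound 4 (0.66 log units; beyond the scatter) on this reasoning. The estimate for compound 4 is 2600 nM with a range of 1200 nM to 5500 nM expected to cover most repeat measurements.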

Compound 4, half-maximal inhibitory concentration: 3740 nM
For compound 4 the middle estimate is 1.4-fold (0.16 log units) below the measured one, within the range that was stated.
By their numbers in this assay, from the lowest: compounds 2, 4 and 1 (each within the scatter of the next); then compound 3.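

In this assay, a 3.2-fold lower number from compound 3 to compound 4 (0.50 log units; beyond the scatter), so a second halogen-bearing ring on this saturated chain carbon also gives a lower number than hydrogen does. The lower number therefore does not belong to 4-fluorophenyl alone, and the pattern now holds for both compounds that carry a ring at this place, with no compound shown going against it. The halogen swap shows a 1.4-fold higher number from compound 2 to compound 4 (0.15 log units; within the scatter), so chloro and fluoro on this aromatic carbon cannot be told apart in these cells, and no data shown explain the effect of the added ring.

From the compounds shown here alone, what a plain phenyl would give at this place remains open, and without it the halogen's own share in the lower number cannot be separated from that of the ring. Also open, going by these compounds, is whether the ring must be aromatic at all, which cyclohexyl would test, and how a larger or charged substituent on the ring, such as a methoxy or a carboxylic acid, would read in this assay.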